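Swapping an acetal for a pyridazinyl ketone on the oleyl chain

This account rests on a few compounds, and the source may have more. Where it says the series, first, only, none or still open, it means among the compounds named here.

Among the compounds with values here, compound 3 `CCCCCCCC/C=C\CCCCCCCC(OC)OC` is the one member of this small set for which only a limit is known: in an assay on isolated protein for inhibition of Fatty-acid amide hydrolase 1 (Homo sapiens) (on this read-out lower numbers stand for stronger inhibition and higher numbers for weaker inhibition), compound 3 gives > 300000 nM, which is the ceiling of the assay rather than a measured number, the point noted in the limit of > 300000 nM in this assay, at which 1 of the 3 values shown sits. Its partners carry a ketone instead of the acetal. Compound 1 `CCCCCCCC/C=C\CCCCCCC(=O)c1nc2cnccc2o1` gives 7.2 nM in this assay, and compound 2 `CCCCCCCC/C=C\CCCCCCC(=O)c1nc2ncccc2o1` gives 2.3 nM. Within the data shown here, the one fully measured step, a 3.1-fold lower number from compound 1 to compound 2 (0.50 log units; beyond the scatter), exchanges one fused heteroaryl ketone for another and is modest.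

Compound 4 `CCCCCCCC/C=C\CCCCCCC(=O)c1cccnn1` is made from compound 3 by the change ((pyridazin-3-yl)carbonyl in place of 2,2-dimethoxyethyl on a saturated chain carbon, six bonds along the chain from a double-bonded chain carbon). Among the measured compounds shown here, no measured step covers this exact exchange; what the numbers do show is that both heteroaryl ketones, compound 1 and compound 2, sit far below the limit at which compound 3 rests, so a large fall in the number is expected. A smaller monocyclic ring than in those two leaves the size of that fall uncertain, so compound 4 is estimated at 60 nM (range 8 nM to 500 nM), the expected step being an at least 5000-fold lower number from compound 3 to compound 4 (3.69 log units; beyond the scatter).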

Compound 4, inhibition constant: 130 nM
Estimate against measurement, compound 4: 2.2-fold (0.34 log units) below; the measured number falls inside the stated range.
By their numbers in this assay, from the lowest: compound 2; then compound 1; then compound 4. At a limit, above all of these: compound 3.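

The step of an at least 2300-fold lower number from compound 3 to compound 4 (3.36 log units; beyond the scatter) shows that on this chain a ketone carrying a single six-membered ring, the (pyridazin-3-yl)carbonyl group, is enough to lie far under the acetal; until now, only ketones with fused rings had shown this. Compound 3 is a limit, so that step gives only a minimum size: the limit of > 300000 nM in this assay, at which 1 of the 4 values shown sits. The ring still matters, since both a 57-fold higher number from compound 2 to compound 4 (1.75 log units; beyond the scatter) and an 18-fold higher number from compound 1 to compound 4 (1.26 log units; beyond the scatter) show that the smaller group on the carbonyl carbon loses much of what the two fused groups reach.

Compound 4 differs from compound 1 and compound 2 in more than one feature of the ring, so the cause of that loss stays open. A lone oxazole or a pyridin-2-yl group on the carbonyl could help separate these features, and a saturated chain would test whether the oleyl double bond matters.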